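A few compounds are considered here, and "the series" means these few. Any claim that something is new, unique, unknown or untested is made for them only; others in the source may bear on it.

The measured compounds:

compound 1, `O=C1[C@H]2[C@H](ON(c3ccccc3)[C@@H]2c2coc3ccc(F)cc3c2=O)C(=O)N1c1ccccc1` — > 60000 nM
compound 2, `O=c1c([C@@H]2C[C@H](c3ccccc3)ON2c2ccccc2)coc2ccc(Br)cc12` — 60000 nM
compound 3, `O=C1[C@H]2[C@H](ON(c3ccccc3)[C@@H]2c2coc3ccc(Br)cc3c2=O)C(=O)N1c1ccccc1` — 13300 nM

All three were tested in a functional assay on PC-3 cells (Homo sapiens) for inhibition, read by sulforhodamine B assay, with a stated time of 48 h; a lower number here means a stronger inhibitor, a higher number a weaker inhibitor. For compound 1 the result is a limit of the assay, > 60000 nM, and not a number. Compound 2 gives 60000 nM, the highest of the two numbers recorded; its nearest neighbour is compound 3, which gives 13300 nM, a gap beyond the scatter. Compound 4, `Cc1ccc2occ([C@@H]3C[C@H](c4ccccc4)ON3c3ccccc3)c(=O)c2c1`, has not yet been measured. It differs from compound 2 by one change: methyl in place of bromo on an aromatic carbon. Only one measured step touches a substituent at this position, an at least 4.5-fold lower number from compound 1 to compound 3 (0.65 log units; beyond the scatter), but that step ran between two halogens on a different core and is bounded by a limit, as shown by the limit of > 60000 nM in this assay, at which 1 of the 3 values shown sits, so it gives only a weak hint of how much a swap here can move the number. Compound 4 is therefore expected to sit close to compound 2, with a step of a 1.2-fold lower number from compound 2 to compound 4 (0.08 log units; within the scatter), and its estimated value is 50000 nM, between 15000 nM and 150000 nM.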

Compound 4, half-maximal inhibitory concentration: > 60000 nM
Compound 4 gave a limit, no number; the forecaster's own chance of this, stated with the estimate: 45%; at least 1.2-fold (0.07 log units) between middle value and limit.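

Methyl in place of bromo on an aromatic carbon of the core of compound 2 gives a number no lower from compound 2 to compound 4 (the limit leaves the size open) in this assay, so this swap brings no gain, though its size cannot be read. Compound 4 gives > 60000 nM, which is a limit of the assay and not a number. This position now shows the same picture on both cores: compound 2 and compound 3, which carry bromo, give numbers, whereas compound 4 and compound 1, which do not, stop at the limit: the limit of > 60000 nM in this assay, at which 2 of the 4 values shown sit.

The compounds shown leave open how far compound 4 lies from compound 2, and whether bromo itself matters or only the loss of it can be seen here. They also leave open how an amine or a methoxy group on this aromatic carbon would read.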